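Opening the Acetonide: A Diol Analogue Awaits Testing

The source may hold more compounds than are shown below. What is called first, only, known or untested is meant among the compounds shown, and "the series" means these compounds.

Of the compounds shown here, three that share the same core have been tested in a functional assay on A-375 cells (Homo sapiens) for cytotoxicity, read by MTT assay, with a stated time of 72 h; on this read-out higher numbers stand for weaker inhibition and lower numbers for stronger inhibition. Compound 1, `CN(C)CCCCn1c2c(c3ccccc31)C(=O)c1c[n+]([O-])c3ccccc3c1C2=O`, gives 470 nM in this assay. Compound 2, `O=C1c2c[n+]([O-])c3ccccc3c2C(=O)c2c1c1ccccc1n2CCN1CCCC1`, gives 430 nM. Compound 3, `CC1(C)OC[C@@H](Cn2cc(Cn3c4c(c5ccccc53)C(=O)c3c[n+]([O-])c5ccccc5c3C4=O)nn2)O1`, gives 450 nM. The only single-point comparison among these three is the step of a 1.1-fold lower number from compound 1 to compound 2 (0.04 log units; within the scatter), which changes the side chain on the aromatic nitrogen and leaves the number essentially where it was. Compound 3 sits among the other two, its number within the scatter of both, nearest to compound 1 and furthest from compound 2.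

The next compound, compound 4, `O=C1c2c[n+]([O-])c3ccccc3c2C(=O)c2c1c1ccccc1n2Cc1cn(C[C@H](O)CO)nn1`, differs from compound 3 at one place: 1,2-dihydroxyethyl in place of 2,2-dimethyl-1,3-dioxolan-4-yl on a saturated chain carbon bound to an aromatic nitrogen. Within the data shown here, no measured step touches this part of the molecule, so the only guidance is indirect: the one step that does exist, between compound 1 and compound 2, shows that changing the group attached to the aromatic nitrogen left the number unchanged within the scatter, and all three measured compounds cluster together despite quite different side chains. On that basis the step of no change at the digits printed from compound 3 to compound 4 (within the scatter) is expected to stay within the scatter. Compound 4 is therefore estimated to give about 450 nM in this assay, with a likely range from 200 nM to 1000 nM.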

Compound 4, half-maximal inhibitory concentration: 350 nM
Compound 4: the middle estimate sits 1.3-fold (0.11 log units) above what was measured; the measured number falls inside the stated range.
By their numbers in this assay, from the lowest: compounds 4, 2, 3 and 1 (each within the scatter of the next).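

Swapping the 2,2-dimethyl-1,3-dioxolan-4-yl ring for the open 1,2-dihydroxyethyl group gives a 1.3-fold lower number from compound 3 to compound 4 (0.11 log units; within the scatter) in this assay and shows that, at this place on the side chain, removing the ring and adding two hydrogen-bond donors leaves the number inside the usual scatter. The larger swaps read the same way, with 1-(2,3-dihydroxypropyl)-1H-1,2,3-triazol-4-yl replacing (pyrrolidin-1-yl)methyl in a 1.2-fold lower number from compound 2 to compound 4 (0.09 log units; within the scatter) and replacing 3-(dimethylamino)propyl in a 1.3-fold lower number from compound 1 to compound 4 (0.13 log units; within the scatter) so that a side chain with a neutral diol end and side chains with an amine all stay within the scatter of one another. Nothing measured alongside these numbers accounts for how little the side chain matters here.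

Still open, as far as these compounds go, is how a carboxylic acid, a single hydroxyl or a methyl ether at the end of this chain would read in this assay and whether a much longer chain would finally move the number beyond the scatter. Also open is whether the mirror-image form of the 1,2-dihydroxyethyl group would read the same, since only one defined stereocentre arrangement appears among these compounds.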